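Fluoro on the benzyl ring of compound 1

This account rests on a few compounds, and the source may have more. Where it says the series, first, only, none or still open, it means among the compounds named here.

Compound 1, `OC[C@H]1O[C@@H](n2cnc3c(NCc4ccccc4Cl)ncnc32)[C@H](O)[C@@H]1O`, is the parent of this small set. In a functional assay on MCF cells (Homo sapiens) for antiproliferative activity, with a stated time of 72 h (a higher number here means a weaker inhibitor, a lower number a stronger inhibitor), compound 1 gives > 166000 nM, which is a limit of the assay and not a number. Compound 2, `COc1cccc(CNc2ncnc3c2ncn3[C@@H]2O[C@H](CO)[C@@H](O)[C@H]2O)c1`, gives > 166000 nM in this assay, again a limit rather than a number. Compound 3, `OC[C@H]1O[C@@H](n2cnc3c(NCc4ccc(Cl)c(Cl)c4)ncnc32)[C@H](O)[C@@H]1O`, gives 88800 nM in this assay. The readable steps among them are an at least 1.8-fold lower number from compound 1 to compound 3 (0.27 log units; that floor lies within the scatter) and an at least 1.8-fold lower number from compound 2 to compound 3 (0.27 log units; that floor lies within the scatter); the step that the two limits leave unreadable from compound 1 to compound 2 cannot be read. Two of the three values sit at the limit of > 166000 nM in this assay, at which 2 of the 3 values shown sit, so compound 1 stands at the edge of what this assay reports.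

Compound 4 is `OC[C@H]1O[C@@H](n2cnc3c(NCc4ccc(F)cc4Cl)ncnc32)[C@H](O)[C@@H]1O`. It differs from compound 1 as follows: fluoro in place of hydrogen on an aromatic carbon. For the measured compounds named here, no measured step adds a fluoro to the benzyl ring, so none bears directly on this change; the steps that are known exchange the whole aryl group and reach only the floor of the scatter, as the step from compound 1 to compound 3 shows. The expected step of an at least 1.1-fold lower number from compound 1 to compound 4 (0.04 log units; that floor lies within the scatter) is therefore small, with a fair chance that compound 4 again reaches only a limit. For compound 4 the expected value in this assay is 150000 nM, estimated between 60000 nM and 330000 nM.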

Compound 4, half-maximal inhibitory concentration: > 166000 nM
Compound 4 ended at the assay's limit (the forecaster's own chance of this, stated with the estimate: 55%); at least 1.1-fold (0.04 log units) between middle value and limit.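

Fluoro on the aromatic carbon para to a large group, which turns the 2-chlorobenzyl group of compound 1 into the 2-chloro-4-fluorobenzyl group of compound 4, does not bring the series to a measurable value in this assay, so this position has now been tested directly and gives no readable gain. Compound 4 has a limit rather than a number, as do compound 1 and compound 2, and the steps to compound 4 from those two cannot be read. The one readable new step is an at least 1.8-fold higher number from compound 3 to compound 4 (0.27 log units; that floor lies within the scatter), so compound 3 keeps the only number in the set, though its separation from the others is not shown to exceed the scatter, and the set now sits mostly at the edge of the assay: the limit of > 166000 nM in this assay, at which 3 of the 4 values shown sit.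

Any effect of fluoro at this position on compounds weaker than the limit stays hidden, so the size and even the direction of the change remain unknown. Going by these compounds, it also remains open whether an amine, a carboxylic acid or a methoxy group on this same aromatic carbon would give a value rather than a limit, or whether fluoro would have a readable effect on the 3,4-dichlorobenzyl group of compound 3.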